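Swapping Isopropylamino for Diethylamino on a Shared Side Chain

The source may report more compounds than this note shows. Statements on the series, on what has been measured and on what is new or still open speak of the compounds shown alone.

In a functional assay on HUVEC cells (Homo sapiens) for inhibition, read by MTT assay, with a stated time of 24 h, tested at 10 uM (on this read-out lower numbers stand for less inhibition of growth and higher numbers for more inhibition of growth at the one concentration tested), compound 3 `COc1cc2ccc(=O)oc2cc1OCC(O)CNC(C)C` gives 0.1%, level with compound 1 `COc1cc2ccc(=O)oc2cc1OCC(O)CN1CCN(C)CC1` at 0.1% and together the lowest of three numbers, while compound 2 `COc1cc2ccc(=O)oc2cc1OCC(O)CN1CCCCC1` gives 31.4%. Compound 4 `CCN(CC)CC(O)COc1cc2oc(=O)ccc2cc1OC` carries diethylamino in place of isopropylamino on a saturated chain carbon, two bonds along the chain from an oxygen on a saturated carbon. Among the measured compounds shown here, no measured step makes this exact exchange. For the measured compounds named here, the steps that bear on it are no change at the digits printed from compound 1 to compound 3 (within the scatter) and a number 31.3 percentage points lower from compound 2 to compound 3 (beyond the scatter), alongside a number 31.3 percentage points higher from compound 1 to compound 2 (beyond the scatter): among the three amines tried, only the piperidinyl of compound 2 gave a clearly higher number, and the other two sat flat together. With compound 3 at 0.1% the step expected is a number 5.9 percentage points higher from compound 3 to compound 4 (within the scatter), small and uncertain in direction. Compound 4 is therefore estimated at 6%, within a range of 0% to 28%.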

Compound 4, percent growth inhibition at one concentration: 0.5%
Beside the measured number, compound 4's estimate is 5.5 percentage points above it; the range from low to high includes it.
By their numbers in this assay, from the lowest: compounds 1, 3 and 4 (each within the scatter of the next); then compound 2.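

Diethylamino at this place joins the flat group in this assay with a number 0.4 percentage points higher from compound 3 to compound 4 (within the scatter) and a number 0.4 percentage points higher from compound 1 to compound 4 (within the scatter) as its steps. Set against piperidin-1-yl, it gives a number 30.9 percentage points lower from compound 2 to compound 4 (beyond the scatter) and so piperidin-1-yl remains the only one of these four amines set apart from the others. Nothing measured here gives a reason for that gap.

From the compounds shown here alone, whether the higher number belongs to piperidin-1-yl alone or extends to other ring amines stays open. Pyrrolidin-1-yl, azepan-1-yl or morpholin-4-yl on the same chain carbon would bear on that.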